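Propyl for methyl on one ester of compound 1

The source may report more compounds than this note shows. Statements on the series, on what has been measured and on what is new or still open speak of the compounds shown alone.

Compound 1 `COC(=O)C1=C(C)NC(C)=C(C(=O)OC)C1c1csc(-c2ccc(Cl)cc2)n1` is the strongest of the three measured compounds in an assay on isolated protein for antagonist activity at Voltage-dependent L-type calcium channel subunit alpha-1C (Cavia porcellus), with a stated time of 15 min (a lower number here means a stronger inhibitor, a higher number a weaker inhibitor), where compound 1 gives 4430 nM. Compound 2 `CC1=C(C(=O)OCC(C)C)C(c2csc(-c3ccc(Cl)cc3)n2)C(C(=O)OCC(C)C)=C(C)N1`, which carries two larger esters, gives 24900 nM in this assay, and compound 3 `CC1=C(C(=O)OCCc2ccccc2)C(c2csc(-c3ccc(Cl)cc3)n2)C(C(=O)OCCc2ccccc2)=C(C)N1`, with two still larger esters, gives 500000 nM. Both of those values lie beyond the scatter from the value of compound 1, and the two larger esters carry the weaker numbers.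

Compound 4 `CCCOC(=O)C1=C(C)NC(C)=C(C(=O)OC)C1c1csc(-c2ccc(Cl)cc2)n1` differs from compound 1 in a single place: ethyl in place of hydrogen on a saturated chain carbon bound to an oxygen next to a carbonyl group. Only one of the two esters is enlarged, and by a smaller amount than in compound 2 or compound 3. The two measured comparisons both point in the direction of a weaker number when the esters grow, so a modest step in that direction is expected here, smaller than the gap between compound 1 and compound 2. The estimated step from compound 1 to compound 4 is a 1.6-fold higher number from compound 1 to compound 4 (0.20 log units; within the scatter). Compound 4 is thus expected to give about 7000 nM in this assay, within a range from 2500 nM to 20000 nM.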

Compound 4, half-maximal inhibitory concentration: 5920 nM
Estimate against measurement, compound 4: 1.2-fold (0.07 log units) above, and the stated range covers the measured number.
By their numbers in this assay, from the lowest: compounds 1 and 4 (each within the scatter of the next); then compound 2; then compound 3.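

In this assay, the change from methoxycarbonyl to propoxycarbonyl on one ester gives a 1.3-fold higher number from compound 1 to compound 4 (0.13 log units; within the scatter), so this enlargement is not separated from the parent by the assay. Compound 2 and compound 3 differ from compound 1 at both esters and in more than chain length, so they could not show the effect of changing a single ester; compound 4 shows that a propyl group on one ester keeps the number within the scatter. Nothing available explains this result.

The compounds shown leave open whether propyl on both esters would also stay within the scatter of compound 1. They also leave open how a longer chain such as hexyl, or a carboxylic acid in place of this ester, would read in this assay.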